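Amide cap exchange at the valine nitrogen

The source may hold more compounds than are shown below. What is called first, only, known or untested is meant among the compounds shown, and "the series" means these compounds.

Working notes on the series. In an assay on THP-1 cells for displacement of a labelled ligand from C-C chemokine receptor type 1 (Homo sapiens) (on this read-out higher numbers stand for weaker inhibition and lower numbers for stronger inhibition), compound 1 (`CC(C)[C@@H](NC(=O)c1ccc(F)cc1)C(=O)N1CCC(c2ccc(Cl)cc2)CC1`) gives 118 nM. Compound 2 (`O=C(N[C@@H](C(=O)N1CCC(c2ccc(Cl)cc2)CC1)C1CCCCC1)c1ccccc1`) gives 121 nM in this assay; the two numbers sit within the scatter of each other, so compound 1 holds the lowest of the two numbers only nominally, with no real separation from compound 2. Going by the values given here, no step between measured compounds that differ in a single place is available.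

Compound 3 (`CC(C)[C@@H](NC(=O)CC1CC1)C(=O)N1CCC(c2ccc(Cl)cc2)CC1`) is the unmeasured analogue of compound 1. The difference is cyclopropylmethyl in place of 4-fluorophenyl on a carbonyl carbon. Among the compounds with values here, with no measured step to lean on, the expectation rests on the change itself, starting from compound 1 at 118 nM. The step of a 2.5-fold higher number from compound 1 to compound 3 (0.41 log units; beyond the scatter) is expected to run toward weaker inhibition, modestly beyond the scatter. Compound 3 is expected to give 300 nM in this assay, within a range from 100 nM to 1000 nM.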

Compound 3, half-maximal inhibitory concentration: 46 nM
Estimate against measurement, compound 3: 6.5-fold (0.81 log units) above, and the stated range ends above it.
By their numbers in this assay, from the lowest: compound 3; then compounds 1 and 2 (each within the scatter of the next).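

At this position, on a carbonyl carbon whose other neighbour is an amide-type nitrogen, an aromatic ring is not needed to hold the read-out in this assay: cyclopropylmethyl in place of 4-fluorophenyl gives a 2.6-fold lower number from compound 1 to compound 3 (0.41 log units; beyond the scatter) with fewer heavy atoms and a three-membered non-aromatic ring. Going by these compounds alone, compound 1 and compound 2 differ in more than one place and stand within the scatter of each other, so this is the first single change to separate two compounds. Nothing at hand gives a reason for this step.

Open, as far as these compounds go, is whether the ring of cyclopropylmethyl matters, which a straight butyl chain or a cyclopentylmethyl group on the same carbonyl carbon would test. Also open, from the compounds shown here alone, is whether the step carries over to the core of compound 2.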